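The source may hold more compounds than are shown below. What is called first, only, known or untested is meant among the compounds shown, and "the series" means these compounds.

Compound 1 `COc1c(OC(C)C)cc2ccc(-c3cc(=O)c4ccccc4o3)cc2c1OC(C)C`: > 10000 nM
Compound 2 `O=C(/C=C/c1csc2ccccc12)c1ccccc1O`: 5300 nM

Both compounds were tested in a functional assay on MDA-MB-231 cells (Homo sapiens) for antiproliferative activity, read by sulforhodamine B assay, with a stated time of 72 h; a higher number here means a weaker inhibitor, a lower number a stronger inhibitor. In this test, compound 1 gives > 10000 nM, which is a limit of the assay and not a number. For the measured compounds named here, compound 2, at 5300 nM, holds the only actual number available, so it cannot be ranked against a spread of measured values.

The next compound is compound 3 `COc1ccc(O)c(C(=O)/C=C/c2csc3ccccc23)c1`, which has not yet been measured. It differs from compound 2 by methoxy in place of hydrogen on an aromatic carbon, (methoxy in place of hydrogen on an aromatic carbon). The new group sits on a six-membered aromatic ring of carbon only, meta to a large group and para to a hydroxy group.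

Going by the values given here, no measured pair of compounds shows what such a change does in this assay, so the expectation is anchored on compound 2 at 5300 nM. The expected step of a 1.1-fold lower number from compound 2 to compound 3 (0.03 log units; within the scatter) stays within the usual scatter, with no direction favoured. For compound 3 the estimated value is 5000 nM, with an expected range from 1800 nM to 13000 nM.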

Compound 3, half-maximal inhibitory concentration: 760 nM
For compound 3 the middle estimate is 6.6-fold (0.82 log units) above the measured one; the measured number lies below the stated range.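

In this assay, for the compounds shown here, methoxy in place of hydrogen gives a 7.0-fold lower number from compound 2 to compound 3 (0.84 log units; beyond the scatter), the first step that shows what a single change does to the number. The change is small, adding one oxygen and one carbon and no ring, yet the step shows that this place, on the six-membered aromatic ring of carbon only, meta to a large group and para to a hydroxy group, accepts a substituent and that the number falls when it does. Going by these compounds alone, nothing at hand accounts for this fall, and the only further value is a limit that bears on no single-place comparison.

On these data alone, this reading rests on one group at one place, so it remains open whether an ethoxy group, a chlorine atom or an amine at the same carbon would move the number in the same direction or by a similar amount. As far as these compounds go, it also remains open whether methoxy on another carbon of this ring would give a comparable step, or whether the effect depends on this particular place.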